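Adding a Methyl to Compound 3

A few compounds are considered here, and "the series" means these few. Any claim that something is new, unique, unknown or untested is made for them only; others in the source may bear on it.

In a physicochemical assay for lipophilicity, read by HPLC, at pH 7.4 (on this read-out lower numbers stand for lower lipophilicity and higher numbers for higher lipophilicity), compound 3 `Cc1ccoc1C(=O)Nc1cccc(-c2nc3ncccc3o2)c1` gives 2.9. Compound 1 `Cc1ccoc1C(=O)Nc1ccc(F)c(-c2nc3ncccc3o2)c1` gives 2.9 and compound 2 `Cc1ccc(NC(=O)c2ccoc2)cc1-c1nc2ncccc2o1` gives 2.7, so all three sit within the scatter of one another. The next compound to be measured is compound 4 `Cc1ccc(NC(=O)c2occc2C)cc1-c1nc2ncccc2o1`, whose structure differs from that of compound 3 by methyl in place of hydrogen on an aromatic carbon.

Among the compounds with values here, only one measured step changes a single place on an aromatic carbon. Putting hydrogen in place of fluoro gave no change at the digits printed from compound 1 to compound 3 (within the scatter). Within the data shown here, no measured step adds a methyl, so the evidence is thin. The forecast rests on that one quiet step and on the single carbon that enters. A small upward move in this assay seems the likeliest outcome, and it may not clear the scatter. The expected step is a number 0.20 log units higher from compound 3 to compound 4 (within the scatter). The estimated value for compound 4 is 3.1, with an expected range from 2.8 to 3.4.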

Compound 4, distribution coefficient: 3.3
Compound 4: the middle estimate sits 0.20 log units below what was measured; low and high end bracket the measured number.
By their numbers in this assay, from the lowest: compounds 2, 1 and 3 (each within the scatter of the next); then compound 4.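

In this assay the place on the six-membered aromatic ring of carbon only now proves able to move the number, since methyl in place of hydrogen gives a number 0.40 log units higher from compound 3 to compound 4 (beyond the scatter) where hydrogen in place of fluoro had given no change at the digits printed from compound 1 to compound 3 (within the scatter) at that same place. Methyl in place of fluoro gives a number 0.40 log units higher from compound 1 to compound 4 (beyond the scatter) and so methyl stands apart from both of the other groups, which do not separate from each other. With that methyl held in place, 3-methylfuran-2-yl in place of furan-3-yl on a carbonyl carbon gives a number 0.60 log units higher from compound 2 to compound 4 (beyond the scatter) and so the furan end of the molecule counts as well.

As far as these compounds go, whether a longer chain such as ethyl, an amine or a carboxylic acid at this place would carry the number further stays open, and a single methyl sets no trend. Nothing available here says why the methyl moves the number.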